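Methyl groups on a fused ring in a cytotoxicity series

The compounds below may be only part of what the source reports. "The series", "measured", "known", "first", "only" and "open" are said of these compounds alone.

Three compounds have been measured in a functional assay on HepG2 cells (Homo sapiens) for cytotoxicity, read by MTT assay, with a stated time of 48 h; on this read-out higher numbers stand for weaker inhibition and lower numbers for stronger inhibition:

Compound 1, `COc1cc(/C=C/C(=O)/C=C/c2nc3ccccc3n2C)ccc1O`, gives 2900 nM.
Compound 2, `COc1cc(/C=C/C(=O)/C=C/c2nc3c(C)cccc3n2C)ccc1O`, gives 1900 nM.
Compound 3, `COc1ccc(/C=C/C(=O)/C=C/c2nc3c(C)cccc3n2C)cc1O`, gives 14700 nM.

Compound 1 and compound 2 differ in one place only: methyl in place of hydrogen on an aromatic carbon. This change gives a 1.5-fold lower number from compound 1 to compound 2 (0.18 log units; within the scatter), a step too small to be told apart from repeat measurements of the same compound. Compound 3 has a different core from compound 1, and the difference between the two cores is not broken down here. What the values show is that compound 3 gives the highest of the three numbers, and its gaps to compound 1 and to compound 2 both lie beyond the scatter, so compound 3 is the weakest inhibitor of the three in this assay.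

Compound 4, `COc1ccc(/C=C/C(=O)/C=C/c2nc3c(C)c(C)ccc3n2C)cc1O`, has not been measured yet. It differs from compound 3 in one place: methyl in place of hydrogen on an aromatic carbon. Going by the values given here, this is the same kind of change as the one from compound 1 to compound 2, but the place is not the same: in compound 2 the entering methyl sits ortho to a fused ring and meta to a fused ring, whereas in compound 4 it sits ortho to a methyl group, meta to a fused ring and para to a fused ring. The expected step for compound 4 is a 1.3-fold lower number from compound 3 to compound 4 (0.13 log units; within the scatter), a change of about the same small size as a 1.5-fold lower number from compound 1 to compound 2 (0.18 log units; within the scatter), and this rests on that single earlier step alone. Compound 4 is therefore expected to give about 11000 nM in this assay. For compound 4 the estimate is expected to fall between 5000 nM and 25000 nM.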

Compound 4, half-maximal inhibitory concentration: 3900 nM
Estimate against measurement, compound 4: 2.8-fold (0.45 log units) above; the measured number lies below the stated range.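

In this assay, methyl in place of hydrogen on an aromatic carbon gives a 3.8-fold lower number from compound 3 to compound 4 (0.58 log units; beyond the scatter), while the same kind of change on the other core gave a 1.5-fold lower number from compound 1 to compound 2 (0.18 log units; within the scatter). Only the newer step stands clear of the scatter on its own, yet set side by side the two steps cannot be told apart: the same change on two cores in this assay, a 1.5-fold lower number (0.18 log units; within the scatter) from compound 1 to compound 2 and a 3.8-fold lower number (0.58 log units; beyond the scatter) from compound 3 to compound 4, 2.5-fold (0.39 log units) apart, within the scatter of two such steps. This shows that the two cores do not measurably disagree about this change, but it does not show that the step has the same size on both, and with the methyl entering at a different place in each pair, the effect of the core cannot be separated from the effect of the place.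

The compounds shown leave open what the methyl would do on the core of compound 1 at the place it holds in compound 4, ortho to a methyl group, and on the core of compound 3 at the place it holds in compound 2. They also leave open whether another group at the place taken by the new methyl, such as an ethyl group, a longer chain, an amine or a carboxylic acid, would move the number in the same direction.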